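The compounds below may be only part of what the source reports. "The series", "measured", "known", "first", "only" and "open" are said of these compounds alone.

Of the compounds shown here, three built on one shared core have been tested in a functional assay on cells (Oocyte) for inhibition of Voltage-dependent T-type calcium channel subunit alpha-1H (Homo sapiens), tested at 100 uM; a higher number here means more inhibition at the concentration tested (going by the name of the read-out), a lower number less inhibition. Compound 3 `O=C(CC1c2ccccc2N=C(N2CCOCC2)N1c1ccccc1)OCc1ccccc1` gives 20.9%. Compound 2 `O=C(CC1c2ccccc2N=C(N2CCCCC2)N1c1ccccc1)OCc1ccccc1` gives 15.6%, and compound 1 `CN1CCN(C2=Nc3ccccc3C(CC(=O)O)N2c2ccccc2)CC1` gives 15%. Although the number of compound 3 is the largest of the three, its gaps to compound 2 and to compound 1 both lie within the scatter, so the three compounds are not separated from one another.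

Within the data shown here, only one measured step changes the group on the carbon with a double bond to nitrogen, which is the place that matters here: a number 5.3 percentage points higher from compound 2 to compound 3 (within the scatter). That swap of one saturated ring for another left the read-out essentially unchanged.

Compound 4 `CN1CCN(C2=Nc3ccccc3C(CC(=O)OCc3ccccc3)N2c2ccccc2)CC1` differs from compound 3 by 4-methylpiperazin-1-yl in place of morpholin-4-yl on a carbon with a double bond to nitrogen. Compound 1 carries the same 4-methylpiperazin-1-yl group and shows 15%, again in the same band as the others.

Because a number 5.3 percentage points higher from compound 2 to compound 3 (within the scatter) stayed within the scatter, and because compound 1 with this group gives 15%, the step of a number 3.9 percentage points lower from compound 3 to compound 4 (within the scatter) is expected to stay within the scatter as well, in no particular direction. Compound 4 is therefore estimated at 17%. The expected range for compound 4 runs from 8% to 28%.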

Compound 4, a percentage reported as inhibition, at one concentration (the size of the read-out at that concentration, not a potency): 32.7%
Beside the measured number, compound 4's estimate is 15.7 percentage points below it; the measured number lies above the stated range.
By their numbers in this assay, from the lowest: compounds 1, 2 and 3 (each within the scatter of the next); then compound 4.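

The position on the carbon with a double bond to nitrogen does respond to the group placed there in this assay, which the earlier swap of one saturated ring for another could not show: 4-methylpiperazin-1-yl gives a higher number than morpholin-4-yl (a number 11.8 percentage points higher from compound 3 to compound 4 (beyond the scatter)) and than piperidin-1-yl (a number 17.1 percentage points higher from compound 2 to compound 4 (beyond the scatter)). Both steps are modest, and the groups compared are all six-membered non-aromatic rings, so a change within that ring type is enough to move the read-out. The new group does not act alone, however: with 4-methylpiperazin-1-yl held constant, benzyl in place of hydrogen on the oxygen next to the carbonyl group also raises the number (a number 17.7 percentage points higher from compound 1 to compound 4 (beyond the scatter)), so among the compounds shown, the higher number appears only when this group and benzyl occur together.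

No measurement shown explains why 4-methylpiperazin-1-yl gives a higher number than the other two rings. The compounds leave open whether the methyl group on the piperazine matters, as a piperazine with a hydrogen on that nitrogen would test, and whether an open-chain amine such as dimethylamino behaves like the ring groups here.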